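The compounds below may be only part of what the source reports. "The series", "measured", "known", "first", "only" and "open" are said of these compounds alone.

Measured in a functional assay on A-375 cells (Homo sapiens) for antiproliferative activity, read by MTT assay, with a stated time of 72 h; a higher number here means a weaker inhibitor, a lower number a stronger inhibitor:
Compound 1 `COc1cccc(N2C(=O)COc3ccc(-c4cnc(Cl)c(NS(=O)(=O)c5ccc(F)cc5)c4)cc32)c1`: > 40000 nM, a limit
Compound 2 `COc1cccc(N2C(=O)COc3ccc(-c4cnc(OC)c(NS(=O)(=O)c5ccc(F)cc5)c4)cc32)c1`: > 40000 nM, a limit

Compound 2 has no number of its own, only the limit > 40000 nM. Both measured compounds share this ceiling: the limit of > 40000 nM in this assay, at which 2 of the 2 values shown sit. Going by the values given here, the one measured step is a step that the two limits leave unreadable from compound 1 to compound 2, so it offers no size to carry forward, and it concerns a different part of the molecule.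

Compound 3 `COc1ncc(-c2ccc3c(c2)N(C2CC2)C(=O)CO3)cc1NS(=O)(=O)c1ccc(F)cc1` keeps the rest of compound 2 but carries cyclopropyl in place of 3-methoxyphenyl on an amide-type nitrogen in a ring. Among the compounds with values here, no measured step covers a change at this place, so the expectation is only a loose one: a modest gain in strength in this assay, with a real chance that compound 3 also returns only a limit. The expected change is an at least 2.6-fold lower number from compound 2 to compound 3 (0.42 log units; beyond the scatter). For compound 3 the estimated value is 15000 nM, with an expected range of 1500 nM to 40000 nM.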

Compound 3, half-maximal inhibitory concentration: 23900 nM
Estimate against measurement, compound 3: 1.6-fold (0.20 log units) below; measured number inside the range.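

Compound 3 is the first compound here to give a number instead of a limit in this assay, and the change that brings this about sits on the amide-type nitrogen in a ring, while the other two compounds stay at the ceiling: the limit of > 40000 nM in this assay, at which 2 of the 3 values shown sit.

The step is an at least 1.6-fold lower number from compound 2 to compound 3 (0.22 log units; that floor lies within the scatter), and that size is only a floor, since compound 2 has a limit and not a number. The position therefore accepts the much smaller cyclopropyl in place of 3-methoxyphenyl with no loss in this assay, yet compound 3 at 23900 nM remains a weak inhibitor.

The compounds shown do not tell whether any gain comes from cyclopropyl itself or simply from losing the aromatic ring. A methyl group, a longer chain or a chain ending in an amine on this nitrogen would help separate those two readings.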